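Dimethylamino in place of methoxy: working notes

A few compounds are considered here, and "the series" means these few. Any claim that something is new, unique, unknown or untested is made for them only; others in the source may bear on it.

Measured in a functional assay on MCF-10A cells (Homo sapiens) for antiproliferative activity, with a stated time of 48 h; a lower number here means that less compound is needed, a higher number that more compound is needed for the effect:
- compound 1 `COc1ccc2nc(C)cc(NCc3cccc(F)c3)c2c1`: 11300 nM
- compound 2 `COc1ccc(CNc2cc(C)nc3ccc(OC)cc23)cc1`: 7000 nM
- compound 3 `COc1cccc(CNc2cc(C)nc3ccc(OC)cc23)c1`: 9700 nM

Compound 3, at 9700 nM, lies within the scatter of both other measured compounds, so no order can be drawn among the three in this assay.

The next compound is compound 4 `COc1ccc2nc(C)cc(NCc3cccc(N(C)C)c3)c2c1`, with dimethylamino in place of methoxy on an aromatic carbon, meta to a large group: dimethylamino in place of methoxy on an aromatic carbon.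

For the measured compounds named here, only one measured step bears on this place, the exchange of fluoro for methoxy, a 1.2-fold lower number from compound 1 to compound 3 (0.07 log units; within the scatter). That step is small and stays within the scatter. Going by the values given here, no measured compound carries dimethylamino, so this support is indirect, and the expected range is kept wide. No change beyond the scatter is expected in this assay.

The estimated step is a 1.1-fold lower number from compound 3 to compound 4 (0.06 log units; within the scatter).

The estimate for compound 4 is 8500 nM, with an expected range of 3500 nM to 18000 nM.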

Compound 4, half-maximal effective concentration: 14000 nM
For compound 4 the middle estimate is 1.6-fold (0.22 log units) below the measured one, and the stated range covers the measured number.
By their numbers in this assay, from the lowest: compounds 2, 3, 1 and 4 (each within the scatter of the next).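

In this assay dimethylamino on this aromatic carbon, meta to a large group, now has a direct reading: the exchange for methoxy gives a 1.4-fold higher number from compound 3 to compound 4 (0.16 log units; within the scatter) and the exchange for fluoro gives a 1.2-fold higher number from compound 1 to compound 4 (0.09 log units; within the scatter) as the second reading. Together with the earlier step between fluoro and methoxy, this place has now carried three different groups without any step beyond the scatter, so none of the three is set apart from the others here. Nothing at hand bears on a cause for these small steps.

Still open, from the compounds shown here alone, is whether any group at this carbon moves the number beyond the scatter, as a carboxylic acid or a longer chain such as butoxy might. The compounds shown also leave open whether changes on the shared core would move it.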